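The source may report more compounds than this note shows. Statements on the series, on what has been measured and on what is new or still open speak of the compounds shown alone.

Measured so far:
compound 1, `CN(C)C(=O)c1cc2cnc(Nc3ccc(S(=O)(=O)NCCCCN=C=S)cc3)nc2n1C1CCCC1` — 101%
compound 2, `CN(C)C(=O)c1cc2cnc(Nc3ccc(S(=O)(=O)NCCCCCN=C=S)cc3)nc2n1C1CCCC1` — 102%
compound 3, `CN(C)C(=O)c1cc2cnc(Nc3ccc(C(=O)NCCCCCCN=C=S)cc3)nc2n1C1CCCC1` — 100%

All three values come from a functional assay on A549 cells (Homo sapiens) for inhibition, read by CCK-8 assay, with a stated time of 72 h, tested at 10 uM; a lower number here means a weaker effect, a higher number a stronger effect of the compound at the concentration tested. Compound 3 differs from compound 1 in its core, by a group of 12 heavy atoms (8 carbon, 2 nitrogen, 1 oxygen, 1 sulfur; no ring) in place of a group of 11 heavy atoms (5 carbon, 2 nitrogen, 2 oxygen, 2 sulfur; no ring), on an aromatic carbon, and its value sits within the scatter of both compound 1 and compound 2, so no order among the three is claimed.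

Within the core of compound 1, compound 2 carries a group of 4 heavy atoms (2 carbon, 1 nitrogen, 1 sulfur; no ring) in place of a group of 3 heavy atoms (1 carbon, 1 nitrogen, 1 sulfur; no ring), on a saturated chain carbon, four bonds along the chain from a sulfonamide nitrogen; the measured step was a number 1 percentage points higher from compound 1 to compound 2 (within the scatter). The unmeasured compound 4, `CN(C)C(=O)c1cc2cnc(Nc3ccc(C(=O)NCCCCCCCN=C=S)cc3)nc2n1C1CCCC1`, carries the same kind of change on the core of compound 3: a group of 4 heavy atoms (2 carbon, 1 nitrogen, 1 sulfur; no ring) in place of a group of 3 heavy atoms (1 carbon, 1 nitrogen, 1 sulfur; no ring), on a saturated chain carbon, six bonds along the chain from an amide-type nitrogen. The surroundings are not identical, since in compound 2 the change sits four bonds along the chain from a sulfonamide nitrogen, whereas in compound 4 it sits six bonds along the chain from an amide-type nitrogen.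

For compound 4 the expected step in this assay is no change at the digits printed from compound 3 to compound 4 (within the scatter), set beside the measured one, and rests on compound 1 to compound 2 having given a number 1 percentage points higher from compound 1 to compound 2 (within the scatter) with nothing else in the series pointing elsewhere. Compound 4 is therefore estimated at 100%, between 94% and 105%.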

Compound 4, a percentage reported as inhibition, at one concentration (the size of the read-out at that concentration, not a potency): 101%
The estimate for compound 4 lay 1 percentage points below the measured number; low and high end bracket the measured number.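

In this assay, placing the group of 4 heavy atoms in place of the group of 3 heavy atoms on the core of compound 3 gave a number 1 percentage points higher from compound 3 to compound 4 (within the scatter), and the step matches the one on the sulfonamide core: the same change on two cores in this assay, a number 1 percentage points higher (within the scatter) from compound 1 to compound 2 and a number 1 percentage points higher (within the scatter) from compound 3 to compound 4, 0 percentage points apart, within the scatter of two such steps. Within the data shown here, the change therefore leaves the read-out within the scatter on both cores at the single concentration tested, but the comparison rests on only two pairs, and neither step shows that the change has any effect of its own. As the read-out is not a potency, these values cannot show whether the change alters potency on either core.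

Still open is whether a longer chain than that of compound 4 would keep the read-out of this assay within the scatter of these compounds. On these data alone, it is equally open how an amine or a carboxylic acid would read in place of the group changed here.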